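Ethylamino in Place of Ethyl: Expected Cytotoxicity

The source may report more compounds than this note shows. Statements on the series, on what has been measured and on what is new or still open speak of the compounds shown alone.

Of the compounds shown here, two have so far been tested in an ADME assay on CHO cells (Cricetulus griseus) for cytotoxicity, read by MTT assay; on this read-out higher numbers stand for weaker inhibition and lower numbers for stronger inhibition. Compound 1, `Cc1cc(C)n(-c2nc(-c3ccc(F)cc3)c(C(=O)O)c(=O)[nH]2)n1`, gives > 50000 nM, which is a limit of the assay and not a number. Among the measured compounds shown here, compound 2, `CCc1cc(C)nn1-c1nc(C(F)(F)F)cc(=O)[nH]1`, gives 108000 nM, and this is the only number recorded in this assay. The remaining measurement is the limit of > 50000 nM in this assay, at which 1 of the 2 values shown sits. For the measured compounds named here, no two measured compounds differ from each other in a single place, so no measured step is available to guide expectations.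

Compound 3, `CCNc1cc(C)nn1-c1nc(C(F)(F)F)cc(=O)[nH]1`, differs from compound 2 by ethylamino in place of ethyl on an aromatic carbon. Going by the values given here, with only one number in hand and no measured step of this kind, the expected change from compound 2 to compound 3 in this assay is a 1.1-fold lower number from compound 2 to compound 3 (0.03 log units; within the scatter), that is, nothing beyond the usual scatter of repeated measurements. Compound 3 is therefore expected to give about 100000 nM, with a range from 40000 nM to 250000 nM, and the assay may well report only a limit.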

Compound 3, half-maximal inhibitory concentration: 8000 nM
Compound 3: middle estimate off by 13-fold (1.10 log units), on the high side; the whole stated range lies above it.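

In this assay, ethylamino in place of ethyl on an aromatic carbon, next to the ring nitrogen and next to the ring atom that bears a large group, gives a 14-fold lower number from compound 2 to compound 3 (1.13 log units; beyond the scatter). Among the compounds shown here, this is the first single-place step in this assay, and it shows what the earlier compounds could not: this position responds strongly to a small change, as the group goes only from 2 heavy atoms to 3 and gains 1 hydrogen-bond donor and 1 hydrogen-bond acceptor. For the compounds shown here, nothing measured so far gives a reason for the size of this step.

The compounds shown leave open whether the step depends on the chain or on the nitrogen alone, which a plain amine, methylamino or propylamino at this position could separate. They also leave open whether the same change would have a similar effect on the core of compound 1.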